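The compounds below may be only part of what the source reports. "The series", "measured", "known", "first", "only" and "open" are said of these compounds alone.

Measured so far in a functional assay on MCF7 cells (Homo sapiens) for cytotoxicity, read by sulforhodamine B assay, with a stated time of 24 h; a lower number here means a stronger inhibitor, a higher number a weaker inhibitor:
- Compound 1 `O=C1Nc2ccc(S(=O)(=O)N3CCOCC3)cc2/C1=N/c1ccc(O)cc1` gives 52700 nM
- Compound 2 `COc1ccc(-c2c(C#N)c(N)n(/N=C3\C(=O)Nc4ccc(S(=O)(=O)N5CCOCC5)cc43)c(=O)c2C#N)cc1` gives 33400 nM
- Compound 3 `CC(=O)N/N=C1\C(=O)Nc2ccc(S(=O)(=O)N3CCOCC3)cc21` gives 56000 nM

Compound 1 sits within the usual scatter of both compound 2 and compound 3, so these measurements give it no firm rank. All of them are weak on this scale, since a strong inhibitor would show a much lower number.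

The next compound is compound 4 `O=C1Nc2ccc(S(=O)(=O)N3CCOCC3)cc2/C1=N/NC(=O)c1ccccc1`, which keeps the core of compound 1 and changes one group: benzamido in place of 4-hydroxyphenyl on a double-bonded nitrogen. In words, benzamido replaces 4-hydroxyphenyl on a double-bonded nitrogen.

The closest guide is the measured step of a 1.1-fold higher number from compound 1 to compound 3 (0.03 log units; within the scatter), where acetamido replaced 4-hydroxyphenyl at that same place. That step stayed within the scatter. Compound 1 also differs on that nitrogen from compound 2 , which gives 33400 nM, and that gap is within the scatter too. Within the data shown here, no measured compound carries benzamido itself, and the evidence is only these few values.

In this assay, no change beyond the scatter is therefore expected, and the estimated step is a 1.1-fold lower number from compound 1 to compound 4 (0.04 log units; within the scatter). For compound 4 the expected value is 48000 nM, with an estimated range from 25000 nM to 90000 nM.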

Compound 4, half-maximal inhibitory concentration: 414000 nM
For compound 4 the middle estimate is 8.6-fold (0.94 log units) below the measured one; the measured number lies above the stated range.
By their numbers in this assay, from the lowest: compounds 2, 1 and 3 (each within the scatter of the next); then compound 4.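

In this assay, the group on the double-bonded nitrogen proves able to shift the number: a 7.9-fold higher number from compound 1 to compound 4 (0.90 log units; beyond the scatter), a step beyond the scatter, whereas a 1.1-fold higher number from compound 1 to compound 3 (0.03 log units; within the scatter) stayed within it. The second comparison narrows the change to one swap, phenyl in place of methyl on a carbonyl carbon, and gives a 7.4-fold higher number from compound 3 to compound 4 (0.87 log units; beyond the scatter); the weaker number therefore goes with the phenyl and not with the carbonyl-bearing link to the core, which compound 3 and compound 4 share. What lies behind this drop cannot be said, as no supporting measurement bears on it.

The compounds shown leave open whether the weaker number is tied to the aromatic ring itself or would also appear with other groups on that carbonyl carbon, such as a cyclohexyl ring or a longer chain like propyl. They also leave open whether an amine or a carboxylic acid on the phenyl ring of compound 4 would bring the number back towards that of compound 3.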